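Nitro in Place of Iodo at a Limit of Detection

The source may hold more compounds than are shown below. What is called first, only, known or untested is meant among the compounds shown, and "the series" means these compounds.

Compound 1 `CC1CC/C(=N\Nc2ccc(Br)cc2)c2ncc(C(=O)O)c(=O)n21`: > 1000 umol/kg
Compound 2 `CC1CC/C(=N\Nc2ccccc2I)c2ncc(C(=O)O)c(=O)n21`: > 1000 umol/kg
Compound 3 `Cc1ccc(N/N=C2\CCC(C)n3c2ncc(C(=O)O)c3=O)cc1`: > 1000 umol/kg

In a functional assay on the whole organism for inhibition, with Rattus norvegicus as the target (on this read-out higher numbers stand for an effect only at larger amounts of compound and lower numbers for an effect already at smaller amounts), compound 1 gives > 1000 umol/kg, which is a limit of the assay and not a number. Compound 2 gives > 1000 umol/kg, likewise a limit. Compound 3 gives > 1000 umol/kg, again a limit. Every value shown thus sits at the limit of > 1000 umol/kg in this assay, at which 3 of the 3 values shown sit. The steps a step that the two limits leave unreadable from compound 1 to compound 2, a step that the two limits leave unreadable from compound 1 to compound 3 and a step that the two limits leave unreadable from compound 2 to compound 3 cannot be read in size. Compound 2 therefore stands at the limit, on equal footing with the two other compounds.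

The unmeasured compound 4 `CC1CC/C(=N\Nc2ccccc2[N+](=O)[O-])c2ncc(C(=O)O)c(=O)n21` differs from compound 2 by nitro in place of iodo on an aromatic carbon. Among the compounds with values here, no measured step bears directly on this change, and the three steps above leave the effect of any change at the group on the amine nitrogen unreadable. A change in this assay beyond the scatter cannot be expected in either direction. The step that the limit leaves unreadable from compound 2 to compound 4 is expected to be small. Compound 4 is therefore estimated at 1500 umol/kg, with a range from 500 umol/kg to 5000 umol/kg, most likely reported only as a limit once more.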

Compound 4, dose for 50% inhibition: > 1000 umol/kg
Compound 4: only a limit was reported; the forecaster's own chance of this, stated with the estimate: 75%; the middle value is on the limit's open side.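

Compound 4, like compound 2, is reported only as a limit of the assay and not as a number, so the step between them cannot be read in size. The compounds shown leave open whether any group on the amine nitrogen changes the dose needed in this assay: the limit of > 1000 umol/kg in this assay, at which 4 of the 4 values shown sit.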